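Swapping the pyrazole for a methylpyrrole: a guess at potency

A few compounds are considered here, and "the series" means these few. Any claim that something is new, unique, unknown or untested is made for them only; others in the source may bear on it.

Measured so far:
compound 1, `CCN(Cc1cc[nH]n1)C(=O)COc1ccc(C)cc1`, "not active" (no number reported);
compound 2, `Cc1ccc(OCC(=O)N(Cc2cccs2)CC(C)C)cc1`, 900 nM;
compound 3, `Cc1ccc(OCC(=O)N(Cc2cccs2)c2nccs2)cc1`, 2240 nM.

All three share the same core, and each was tested in an assay on HEK293 cells for agonist activity at transient receptor potential cation channel subfamily M member 8 (Homo sapiens), read by fluorescence and calcium flux, with a stated time of 15 min; a lower number here means that less compound is needed, a higher number that more compound is needed for the effect. Compound 1 stands apart from the others: for it the outcome was "not active" (no number reported), so there is no number to place it against compound 2 or compound 3.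

Compound 4, `CCN(Cc1cccn1C)C(=O)COc1ccc(C)cc1`, is the untested analogue. It differs from compound 1 in one place: 1-methyl-1H-pyrrol-2-yl in place of 1H-pyrazol-3-yl on a saturated chain carbon bound to an amide-type nitrogen. Going by the values given here, the only measured step concerns a different position on the same nitrogen, namely a 2.5-fold higher number from compound 2 to compound 3 (0.40 log units; beyond the scatter), and it shows that changing one substituent on that nitrogen can shift the result modestly. Among the compounds with values here, no step tells directly what the exchange from compound 1 to compound 4 does, and compound 1 itself gives no number to start from.

The expectation therefore rests on compound 2 and compound 3, whose values show that members of this series can reach measurable activity, while compound 1 shows they need not. Compound 4 is estimated to give 4000 nM, with a range from 900 nM to 20000 nM, and a real chance of no number at all.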

Compound 4, half-maximal effective concentration: 21300 nM
The estimate for compound 4 lay 5.3-fold (0.73 log units) below the measured number; measured number outside the range, above it.
By their numbers in this assay, from the lowest: compound 2; then compound 3; then compound 4.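

Going by these compounds alone, compound 1 has no number to compare, so no step from compound 1 to compound 4 can be read. The compounds shown leave open how far 1-methyl-1H-pyrrol-2-yl in place of 1H-pyrazol-3-yl shifts activity. No evidence shown bears on this result.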